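The source may hold more compounds than are shown below. What is called first, only, known or untested is meant among the compounds shown, and "the series" means these compounds.

Measured in a functional assay on MCF-10A cells (Homo sapiens) for antiproliferative activity, with a stated time of 48 h; on this read-out higher numbers stand for an effect only at larger amounts of compound and lower numbers for an effect already at smaller amounts:
- compound 1 `COc1ccc2nc(C)cc(NCc3ccccc3)c2c1`: 25900 nM
- compound 2 `COc1ccc2nc(C)cc(NCC3CCCN(C)C3)c2c1`: 6400 nM
- compound 3 `COc1ccc2nc(C)cc(NCc3ccccc3F)c2c1`: 14000 nM

Compound 3, at 14000 nM, lies within the scatter of compound 1 and apart from compound 2 (a 2.2-fold higher number from compound 2 to compound 3 (0.34 log units; beyond the scatter)). Compound 4 `COc1ccc2nc(C)cc(NCc3c(F)cccc3F)c2c1` is reached by fluoro in place of hydrogen on an aromatic carbon, ortho to a large group and meta to a fluoro group. Going by the values given here, only one measured step is of the same kind, a 1.9-fold lower number from compound 1 to compound 3 (0.27 log units; within the scatter), and it stays within the scatter. No step beyond the scatter is therefore expected in this assay. The expected step is a 1.2-fold lower number from compound 3 to compound 4 (0.07 log units; within the scatter). Compound 4 is estimated at 12000 nM, with an expected range of 6000 nM to 25000 nM.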

Compound 4, half-maximal effective concentration: 13600 nM
The estimate for compound 4 lay 1.1-fold (0.05 log units) below the measured number, within the range that was stated.
By their numbers in this assay, from the lowest: compound 2; then compounds 4, 3 and 1 (each within the scatter of the next).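

In this assay, fluoro in place of hydrogen on an aromatic carbon, ortho to a large group and meta to a fluoro group, gives a 1.0-fold lower number from compound 3 to compound 4 (0.01 log units; within the scatter). Together with a 1.9-fold lower number from compound 1 to compound 3 (0.27 log units; within the scatter), this makes two fluoro steps on this ring that stay within the scatter, so adding a second fluoro leaves the read-out unmoved. No measured evidence bearing on this result is available.

Still open, going by these compounds, is whether chloro, methoxy or an amine on this aromatic carbon gives a step beyond the scatter. Also open, on these data alone, is whether a longer chain between the ring and the nitrogen on the core changes the read-out.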